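Swapping a Ring for an Amide on a Weak Starting Point

The source may hold more compounds than are shown below. What is called first, only, known or untested is meant among the compounds shown, and "the series" means these compounds.

Compound 1, `Cc1cc(C)c(S(=O)(=O)N2CCC(C3OCC(C)CO3)CC2)c(C)c1`, was tested in a functional assay on DLD-1 cells (Homo sapiens) for antiproliferative activity, read by CellTiter-Glo, with a stated time of 72 h; on this read-out higher numbers stand for weaker inhibition and lower numbers for stronger inhibition. In this assay compound 1 gives > 5000 nM, which is a limit of the assay rather than a number, so its activity is known only as lying beyond that boundary (the limit of > 5000 nM in this assay, at which 1 of the 2 values shown sits). A second measured compound, compound 2, `CC1CCN(C2CCN(S(=O)(=O)c3cccnc3)CC2)CC1`, gives 2400 nM in this assay; it shares no single-point step with compound 1, so the two values are simply shown side by side.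

Compound 3, `CCCC(=O)NC1CCN(S(=O)(=O)c2c(C)cc(C)cc2C)CC1`, has not been measured. It differs from compound 1 on a saturated ring carbon of a six-membered non-aromatic ring with one nitrogen, three ring bonds from the ring nitrogen, where the (propylcarbonyl)amino group enters in place of the six-membered non-aromatic ring with two hetero atoms (a group of 6 heavy atoms (4 carbon, 1 nitrogen, 1 oxygen; no ring) in place of a group of 7 heavy atoms (5 carbon, 2 oxygen; one six-membered non-aromatic ring with 2 hetero atoms), on a saturated ring carbon).

Among the measured compounds shown here, since compound 1 sits at a limit, no measured step guides the direction; the change is expected to bring no shift beyond the scatter, so a number no higher from compound 1 to compound 3 (the limit leaves the size open) is the expected step. Compound 3 is therefore estimated at 5000 nM, within 1500 nM to 20000 nM, with a fair chance that the assay again reports only a limit.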

Compound 3, half-maximal inhibitory concentration: > 5000 nM
Compound 3 gave a limit, no number (the forecaster's own chance of this, stated with the estimate: 55%); the middle value lies on the limit itself.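

Compound 1 and compound 3 both stand at a limit rather than at a number, so the step between them cannot be read: the limit of > 5000 nM in this assay, at which 2 of the 3 values shown sit.

The compounds shown leave open whether the (propylcarbonyl)amino group changes activity at all compared with the ring it replaces, and how far past the limit either compound lies.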